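Moving one chlorine: what to expect for compound 3

A few compounds are considered here, and "the series" means these few. Any claim that something is new, unique, unknown or untested is made for them only; others in the source may bear on it.

Compound 1 `Cc1ccccc1-c1cc2ccc(N(C)C)cc2nc1N`: 6800 nM
Compound 2 `CN(C)c1ccc2cc(-c3cccc(Cl)c3)c(N)nc2c1`: 13000 nM

In a toxicity assay on J774.A1 cells (Mus musculus) for cytotoxicity, read by SYBR Green assay, with a stated time of 1 h (on this read-out lower numbers stand for an effect already at smaller amounts and higher numbers for an effect only at larger amounts of compound), compound 2 gives 13000 nM. Within the data shown here, only one other compound has a number so far, and the two values lie within the usual scatter of each other, so they cannot be told apart.

Compound 3 `CN(C)c1ccc2cc(-c3ccc(Cl)cc3)c(N)nc2c1` has not yet been measured. It differs from compound 2 in one place: 4-chlorophenyl in place of 3-chlorophenyl on an aromatic carbon. In plain words, 4-chlorophenyl stands in place of 3-chlorophenyl on an aromatic carbon, ortho to an amino group. The two compounds have the same atoms, joined differently.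

Among the measured compounds shown here, only one measured step bears on this. It changes the group at the same place, and it is a 1.9-fold higher number from compound 1 to compound 2 (0.28 log units; within the scatter). For the measured compounds named here, a single small step is thin evidence, and no measured compound carries the 4-chlorophenyl group. Even so, no change beyond the scatter is expected in this assay. The expected step is a 1.2-fold lower number from compound 2 to compound 3 (0.07 log units; within the scatter). The estimate for compound 3 is 11000 nM, with a range of 5000 nM to 25000 nM.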

Compound 3, half-maximal effective concentration: 2900 nM
Compound 3: the middle estimate sits 3.8-fold (0.58 log units) above what was measured; the measured number lies below the stated range.
By their numbers in this assay, from the lowest: compound 3; then compounds 1 and 2 (each within the scatter of the next).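

Moving the chlorine around the phenyl ring, with the same atoms in the molecule, is enough to shift the result in this assay: changing 3-chlorophenyl to 4-chlorophenyl gives a 4.5-fold lower number from compound 2 to compound 3 (0.65 log units; beyond the scatter) and so moves the number beyond the scatter, which the earlier change at this place did not do. The 4-chlorophenyl group also separates from 2-methylphenyl, with a 2.3-fold lower number from compound 1 to compound 3 (0.37 log units; beyond the scatter) as the step, so compound 3 has the lowest number of the three and shows its effect on these cells at the smallest amount. Nothing available explains why the location of the chlorine matters here.

The compounds shown cannot tell whether this shift belongs to chlorine itself or would appear with another group at the same location on the phenyl ring, such as a methyl, a methoxy group or an amine. They also leave open how 2-chlorophenyl would compare, which would show whether the result changes steadily as the chlorine moves or whether the 4-chlorophenyl compound stands alone.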